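A few compounds are considered here, and "the series" means these few. Any claim that something is new, unique, unknown or untested is made for them only; others in the source may bear on it.

Working notes on the series. Compound 1 `CC(O)(CSc1cccc(C(F)(F)F)c1)C(=O)Nc1ccc(S(F)(F)(F)(F)F)cc1` and compound 2 `CC(O)(CSc1cccc(OC(F)(F)F)c1)C(=O)Nc1ccc(S(F)(F)(F)(F)F)cc1` share one core; compound 3 `CC(O)(CSc1ccc(C(F)(F)F)cc1)C(=O)Nc1cccc(S(F)(F)(F)(F)F)c1` and compound 4 `CC(O)(CSc1ccc(OC(F)(F)F)cc1)C(=O)Nc1cccc(S(F)(F)(F)(F)F)c1` share another, built from the same atoms joined differently, and the difference between the two cores is not broken down here. In a functional assay on CWR22R cells (Homo sapiens) for antiproliferative activity, read by propidium iodide staining, with a stated time of 96 h (on this read-out higher numbers stand for weaker inhibition and lower numbers for stronger inhibition), compound 1 gives 23400 nM. In this assay compound 2 gives 14000 nM. In this assay compound 3 gives 26900 nM. The numbers of compound 1, compound 2 and compound 3 all lie within the scatter of one another, so no order among the three can be read from them.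

The measured change is trifluoromethoxy in place of trifluoromethyl on an aromatic carbon and it produces a 1.7-fold lower number from compound 1 to compound 2 (0.22 log units; within the scatter). The change still to be measured is trifluoromethoxy in place of trifluoromethyl on an aromatic carbon. It is the same kind of change, not the same: in compound 1 the group sits meta to a large group, in compound 3 it sits para to a large group. For the measured compounds named here, nothing among the measured compounds tests whether that difference of place alters the outcome, so the one measured instance is all that can be leaned on.

Going by the values given here, the step from compound 3 to compound 4 is expected to be a 1.5-fold lower number from compound 3 to compound 4 (0.17 log units; within the scatter), of about the size of the earlier one, because the only measured instance of this change gives a 1.7-fold lower number from compound 1 to compound 2 (0.22 log units; within the scatter). Compound 4 is therefore expected to give 18000 nM in this assay. For compound 4 the expected range runs from 8000 nM to 40000 nM.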

Compound 4, half-maximal inhibitory concentration: 17000 nM
The estimate for compound 4 lay 1.1-fold (0.02 log units) above the measured number; low and high end bracket the measured number.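

In this assay, trifluoromethoxy in place of trifluoromethyl on the core of compound 3 gives a 1.6-fold lower number from compound 3 to compound 4 (0.20 log units; within the scatter). Set beside the step on the core of compound 1, the change carries from one core to the other with no difference that can be read: the same change on two cores in this assay, a 1.7-fold lower number (0.22 log units; within the scatter) from compound 1 to compound 2 and a 1.6-fold lower number (0.20 log units; within the scatter) from compound 3 to compound 4, 1.1-fold (0.02 log units) apart, within the scatter of two such steps This does not show that the change has any effect of its own, since each step lies within the scatter, so the agreement is one between two small steps; nor does it separate core from place, since the two pairs differ in both, and two pairs are too few to support a rule for the series.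

The compounds shown carry only trifluoromethyl and trifluoromethoxy at this aromatic carbon, so they leave open whether a nitrile, a carboxylic acid, an amine or a longer chain there would give a step beyond the scatter in this assay. Also open, as far as these compounds go, is whether replacing the sulfur link with a sulfone, or the hydroxyl with a methoxy group, would move the numbers of this series, which all stay close together here.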